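The compounds below may be only part of what the source reports. "The series", "measured", "known", "first", "only" and "open" are said of these compounds alone.

Measured so far:
compound 1 `CC(C)CNc1ccc(NC(=O)c2cc(Cl)ccc2O)c(Cl)c1` — 60000 nM
compound 2 `O=C(Nc1ccc(NCC2CC2)cc1Cl)c1cc(Cl)ccc1O` — 14400 nM
compound 3 `O=C(Nc1ccc(NCc2ccc(Br)s2)cc1Cl)c1cc(Cl)ccc1O` — 20700 nM

In an ADME assay on A549 cells (Homo sapiens) for cytotoxicity, read by resazurin assay, with a stated time of 48 h (a higher number here means that more compound is tolerated, a lower number that less compound is tolerated), compound 2 stands lowest of the three numbers; compound 3 lies nearest, a 1.4-fold higher number from compound 2 to compound 3 (0.16 log units; within the scatter), and compound 1 furthest, a 4.2-fold lower number from compound 1 to compound 2 (0.62 log units; beyond the scatter). Compound 4 `CC(CCO)Nc1ccc(NC(=O)c2cc(Cl)ccc2O)c(Cl)c1` is not yet measured. Its change from compound 2: 3-hydroxy-1-methylpropyl in place of cyclopropylmethyl on a nitrogen on an aromatic ring. For the measured compounds named here, no measured step covers this exact exchange. The steps that do touch this nitrogen, a 4.2-fold lower number from compound 1 to compound 2 (0.62 log units; beyond the scatter) and a 2.9-fold lower number from compound 1 to compound 3 (0.46 log units; beyond the scatter), were both modest and in the same direction, so substituents here move the number only moderately. For compound 4 a modest step back toward compound 1 is expected, a 2.1-fold higher number from compound 2 to compound 4 (0.32 log units; beyond the scatter), with no strong reason to expect it to pass compound 1. The estimate for compound 4 is therefore 30000 nM, within a range of 10000 nM to 90000 nM.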

Compound 4, half-maximal cytotoxic concentration: 200000 nM
For compound 4 the middle estimate is 6.7-fold (0.82 log units) below the measured one; the measured number lies above the stated range.
By their numbers in this assay, from the lowest: compounds 2 and 3 (each within the scatter of the next); then compound 1; then compound 4.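

In this assay, 3-hydroxy-1-methylpropyl on this nitrogen gives a 14-fold higher number from compound 2 to compound 4 (1.14 log units; beyond the scatter), a 9.7-fold higher number from compound 3 to compound 4 (0.99 log units; beyond the scatter) and a 3.3-fold higher number from compound 1 to compound 4 (0.52 log units; beyond the scatter). This nitrogen substituent can therefore move the number above that of compound 1 as well as below it, and compound 4 is the most tolerated of the four. No measurement on hand accounts for this rise.

Going by these compounds, the hydroxy group and the methyl branch enter together, so their separate shares remain open. An unbranched 3-hydroxypropyl chain, or an amine or carboxylic acid at the chain end, would help separate them.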